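This account rests on a few compounds, and the source may have more. Where it says the series, first, only, none or still open, it means among the compounds named here.

Three compounds have so far been measured in an assay for inhibition of MAP kinase-interacting serine/threonine-protein kinase 1 (Homo sapiens), read by luminescence and ADP-Glo, with a stated time of 2 h; a lower number here means a stronger inhibitor, a higher number a weaker inhibitor:

Compound 1 `O=c1ccc(-c2ccc3cn[nH]c3c2)cn1Cc1ccccc1C(F)(F)F`: 133 nM
Compound 2 `NC(=O)c1cccc(Cn2cc(-c3ccc4cn[nH]c4c3)ccc2=O)c1`: 388 nM
Compound 3 `O=C(N1CCOCC1)n1cc(-c2ccc3cn[nH]c3c2)ccc1=O`: > 2000 nM

All three share the same core and differ only in the group carried on one aromatic nitrogen. From the compounds shown here alone, for compound 3 the result is not a number but a limit of the assay, so its true value is unknown. Compound 3 thus stands at the limit of > 2000 nM in this assay, at which 1 of the 3 values shown sits, and nothing finer can be said about where it lies.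

Compound 4 `O=c1ccc(-c2ccc3cn[nH]c3c2)cn1Cc1ccccc1` has not yet been measured. It differs from compound 3 by benzyl in place of (morpholin-4-yl)carbonyl on an aromatic nitrogen. Among the measured compounds shown here, no measured pair of compounds separated by a single change is available for comparison, so the expectation rests on the whole set. Compound 1 and compound 2 each carry a benzyl with one further group attached, and each gives a value well inside the measurable range. Compound 4 is therefore expected to return a number rather than a limit, and the step from the limit seen for compound 3 is expected to be large and toward stronger inhibition, with an at least 10-fold lower number from compound 3 to compound 4 (1.00 log units; beyond the scatter) as the estimated size. For compound 4 the estimated value in this assay is 200 nM, expected to lie between 70 nM and 600 nM.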

Compound 4, half-maximal inhibitory concentration: 315 nM
Compound 4: middle estimate off by 1.6-fold (0.20 log units), on the low side, within the range that was stated.
By their numbers in this assay, from the lowest: compound 1; then compounds 4 and 2 (each within the scatter of the next). At a limit, above all of these: compound 3.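

In this assay, benzyl in place of (morpholin-4-yl)carbonyl on the aromatic nitrogen gives a measurable number, with an at least 6.3-fold lower number from compound 3 to compound 4 (0.80 log units; beyond the scatter). That size is only a minimum, as the result for compound 3 is a limit of the assay and not a number: the limit of > 2000 nM in this assay, at which 1 of the 4 values shown sits. Among the compounds shown here, the plain benzyl of compound 4 also gives the first reference for groups on that ring: hydrogen in place of trifluoromethyl gives a 2.4-fold higher number from compound 1 to compound 4 (0.37 log units; beyond the scatter), so trifluoromethyl is tied to a modest gain in inhibition, while hydrogen in place of carbamoyl gives a 1.2-fold lower number from compound 2 to compound 4 (0.09 log units; within the scatter), so carbamoyl shows no effect that can be told from scatter.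

From the compounds shown here alone, since the whole group on the nitrogen changes at once, these compounds cannot say whether the carbonyl, the morpholine ring or the presence of the benzyl ring accounts for the step, and a longer chain between that ring and the nitrogen remains untested here. Going by these compounds, it also remains open whether the gain is specific to trifluoromethyl or would extend to a chlorine atom, a methoxy group or an amine on the benzyl ring.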